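Removing a Methyl Two Bonds from the Nitrogen

The source may report more compounds than this note shows. Statements on the series, on what has been measured and on what is new or still open speak of the compounds shown alone.

In a functional assay for inhibition, with Rattus norvegicus as the target (a lower number here means a stronger inhibitor, a higher number a weaker inhibitor), compound 1 `CC(/N=c1\c(O)c(O)\c1=N/[C@H](C)C(C)(C)C)c1ccc(C#N)cc1` gives 6500 nM, and compound 2 `C[C@@H](/N=c1\c(O)c(O)\c1=N/Cc1ccc(C#N)cc1)C(C)(C)C` gives 270 nM. Compound 2 differs from compound 1 by hydrogen in place of methyl on a saturated chain carbon bound to an aromatic carbon and a double-bonded nitrogen, and this change brought a 24-fold lower number from compound 1 to compound 2 (1.38 log units; beyond the scatter). Compound 3 `CCC(C)(C)/N=c1\c(O)c(O)\c1=N/Cc1c(Cl)cccc1Cl` gives 280 nM in this assay; the difference between its core and that of compound 1 is not broken down here. Compound 4 `CC(C)(C)/N=c1\c(O)c(O)\c1=N/Cc1c(Cl)cccc1Cl` differs from compound 3 by hydrogen in place of methyl on a saturated chain carbon, two bonds along the chain from a double-bonded nitrogen. This is the same kind of change as the earlier one, not the same: there the carbon was bound to an aromatic carbon and a double-bonded nitrogen, here it lies two bonds along the chain from a double-bonded nitrogen. A smaller step is expected, a 1.3-fold higher number from compound 3 to compound 4 (0.10 log units; within the scatter), because a 24-fold lower number from compound 1 to compound 2 (1.38 log units; beyond the scatter) arose at a different place. Compound 4 is expected to give 350 nM, between 120 nM and 1000 nM.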

Compound 4, half-maximal inhibitory concentration: 1100 nM
Estimate against measurement, compound 4: 3.1-fold (0.50 log units) below, outside the stated range (above it).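

Replacing this methyl with hydrogen in this assay gives a 3.9-fold higher number from compound 3 to compound 4 (0.59 log units; beyond the scatter) and so a weaker inhibitor. Set beside the earlier removal of a methyl, the step runs the opposite way, so in this series a change of this kind cannot be carried from one core to another as a fixed number: the same change on two cores in this assay, a 24-fold lower number (1.38 log units; beyond the scatter) from compound 1 to compound 2 and a 3.9-fold higher number (0.59 log units; beyond the scatter) from compound 3 to compound 4, 95-fold (1.98 log units) apart, beyond the scatter of two such steps. Among the compounds shown here, this does not show why the two steps part: the two methyl groups sit at different places on different cores, and each place has only a single step.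

Still open, from the compounds shown here alone, is what a longer chain, such as propyl, or an amine would do in place of this methyl. Also open, going by these compounds, is how either change would behave on the core of compound 1.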